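The source may report more compounds than this note shows. Statements on the series, on what has been measured and on what is new or still open speak of the compounds shown alone.

Compound 1 `CC(C)(C)c1csc(N)c1C(=O)c1ccc(Cl)cc1`: in an assay on CHO cells for displacement of a labelled ligand from adenosine receptor A1 (Homo sapiens), read by scintillation counting, tested at 10 uM (a lower number here means less inhibition, a higher number more inhibition at the concentration tested (going by the name of the read-out)), compound 1 gives 1%.
Compound 2 `CC(C)(C)Cc1c(-c2ccc(Cl)c(Cl)c2)sc(N)c1C(=O)c1ccc(Cl)cc1`: in this assay compound 2 gives 1%.

In this assay compound 2 stands level with compound 1 at the digits shown, within the usual scatter; both show almost no inhibition at the concentration tested. Compound 3 `COc1ccc(-c2sc(N)c(C(=O)c3ccc(Cl)cc3)c2CC(C)(C)C)cc1` differs from compound 2 in one place: 4-methoxyphenyl in place of 3,4-dichlorophenyl on an aromatic carbon. Within the data shown here, with only two measured compounds, both at the same low level, there is no measured step to go by. The change is expected to shift the read-out by a number 1 percentage points higher from compound 2 to compound 3 (within the scatter), nothing beyond the scatter. Compound 3 is therefore estimated at 2%, with a range from 0% to 12%.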

Compound 3, a percentage reported as inhibition, at one concentration (the size of the read-out at that concentration, not a potency): 1%
For compound 3 the middle estimate is 1 percentage points above the measured one, within the range that was stated.
By their numbers in this assay, from the lowest: compounds 1, 2 and 3 (each within the scatter of the next).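

In this assay, putting 4-methoxyphenyl in place of 3,4-dichlorophenyl on the aromatic carbon next to the ring sulfur gives no change at the digits printed from compound 2 to compound 3 (within the scatter). This position now has two different aryl groups on record, one with chlorine and one with an oxygen that counts as a hydrogen-bond acceptor, and both show almost no inhibition. No measurement at hand bears on why this exchange leaves the read-out as it is. As far as these compounds go, whether an amine or a carboxylic acid at this position, or a longer chain in place of the neopentyl group, would raise inhibition remains open.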